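Aryl replacement on the amine-bound chain carbon: outlook for compound 4

The source may hold more compounds than are shown below. What is called first, only, known or untested is meant among the compounds shown, and "the series" means these compounds.

Measured compounds:
compound 1, `Cn1cc(CN2CCC[C@H](OCc3cc(Cl)cc(Cl)c3)[C@@H]2c2ccccc2)cn1`, in an assay on isolated protein for activation of cGMP-dependent protein kinase 1 (Homo sapiens), read by ADP-Glo, with stated times of 120 min and 40 min (on this read-out higher numbers stand for an effect only at larger amounts of compound and lower numbers for an effect already at smaller amounts), gives 110000 nM
compound 2, `Clc1cc(Cl)cc(CO[C@H]2CCCN(Cc3ccccc3)[C@H]2c2ccccc2)c1`, reaches only the limit > 200000 nM in this assay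
compound 3, `Clc1cc(Cl)cc(CO[C@H]2CCCN(Cc3cccnc3)[C@H]2c2ccccc2)c1`, gives 112000 nM in this assay

Compound 3 holds the highest of the two numbers, but its nearest neighbour is compound 1 at a 1.0-fold higher number from compound 1 to compound 3 (0.01 log units; within the scatter), so the two are indistinguishable. Compound 2 sits at the assay limit (the limit of > 200000 nM in this assay, at which 1 of the 3 values shown sits).

Compound 4, `Clc1cc(Cl)cc(CO[C@H]2CCCN(Cc3ccc(-c4nn[nH]n4)cc3)[C@H]2c2ccccc2)c1`, differs from compound 3 only in 4-(2H-tetrazol-5-yl)phenyl in place of pyridin-3-yl on a saturated chain carbon bound to an amine nitrogen in a ring. The same carbon has already carried three different aryl groups, and all changes there stayed within the scatter: an at least 1.8-fold higher number from compound 1 to compound 2 (0.25 log units; that floor lies within the scatter) and an at least 1.7-fold lower number from compound 2 to compound 3 (0.25 log units; that floor lies within the scatter), both floors only. Nothing in the series points to a step beyond the scatter for another aryl at this carbon, though the limit on compound 2 leaves open that compound 4 may also run out of range.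

Compound 4 is therefore expected near 130000 nM, between 50000 nM and 300000 nM. The expected step of a 1.2-fold higher number from compound 3 to compound 4 (0.06 log units; within the scatter) is estimated to lie within the scatter.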

Compound 4, half-maximal effective concentration: 74000 nM
The estimate for compound 4 lay 1.8-fold (0.24 log units) above the measured number, and the stated range covers the measured number.
By their numbers in this assay, from the lowest: compounds 4, 1 and 3 (each within the scatter of the next). At a limit, above all of these: compound 2.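

In this assay, going by these compounds alone, 2H-tetrazol-5-yl on an aromatic carbon gives the first step at this position that lies beyond the scatter: an at least 2.7-fold lower number from compound 2 to compound 4 (0.43 log units; beyond the scatter). Compound 2 is a limit of the assay, so this step is only a floor: the limit of > 200000 nM in this assay, at which 1 of the 4 values shown sits. Against the other aryl groups, 4-(2H-tetrazol-5-yl)phenyl, with its 11 heavy atoms, stays within the scatter, with a 1.5-fold lower number from compound 3 to compound 4 (0.18 log units; within the scatter) and a 1.5-fold lower number from compound 1 to compound 4 (0.17 log units; within the scatter), so this larger group gives no step that can be told apart from theirs.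

A carboxylic acid or an amine in place of the 2H-tetrazol-5-yl would show whether the step from compound 2 depends on the tetrazole itself. Compound 4, at 74000 nM, leaves open whether any group on this carbon gives an effect at much smaller amounts.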